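Cyclohexenyl for propyl on a triazole antagonist

A few compounds are considered here, and "the series" means these few. Any claim that something is new, unique, unknown or untested is made for them only; others in the source may bear on it.

Of the compounds shown here, two have been measured in a functional assay on CHO cells for antagonist activity at prostaglandin E2 receptor EP4 subtype (Homo sapiens), read by calcium flux, with a stated time of 15 min; on this read-out lower numbers stand for stronger inhibition and higher numbers for weaker inhibition. Compound 1 `CCCc1nnn(Cc2ccc(C(F)(F)F)cc2)c1C(=O)N[C@@H](C)c1ccc(C(=O)O)cc1` gives 68.8 nM in this assay, the lowest of the two numbers. Compound 2 `C[C@H](NC(=O)c1c(-c2ccccc2)nnn1Cc1ccc(F)cc1)c1ccc(C(=O)O)cc1` gives 330 nM in this assay, a higher number that lies beyond the scatter; compound 2 differs from compound 1 in more than one place, so its value only shows that compound 1 is the more potent of the pair. Compound 3 `C[C@H](NC(=O)c1c(C2=CCCCC2)nnn1Cc1ccc(C(F)(F)F)cc1)c1ccc(C(=O)O)cc1` has not yet been measured. It differs from compound 1 by cyclohex-1-en-1-yl in place of propyl on an aromatic carbon. Going by the values given here, with no single-point step among the measured compounds to lean on, the size of this change can only be guessed; a modest step toward a higher number, possibly within the scatter, is expected. Compound 3 is therefore estimated at 110 nM, with a range from 35 nM to 350 nM, which corresponds to an expected step of a 1.6-fold higher number from compound 1 to compound 3 (0.20 log units; within the scatter).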

Compound 3, half-maximal inhibitory concentration: 183 nM
Beside the measured number, compound 3's estimate is 1.7-fold (0.22 log units) below it; measured number inside the range.
By their numbers in this assay, from the lowest: compound 1; then compounds 3 and 2 (each within the scatter of the next).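

In this assay, going by these compounds alone, the change gives a 2.7-fold higher number from compound 1 to compound 3 (0.42 log units; beyond the scatter) and so provides the first single-place reading at this position on the core of compound 1. Putting cyclohex-1-en-1-yl in place of propyl on this aromatic carbon costs some potency, yet the position still tolerates a six-membered non-aromatic ring of carbon only, and compound 3 keeps measurable inhibition. No data here account for the size of this step.

With only these two groups compared at this position, the compounds shown cannot separate the contribution of the ring from that of its double bond, which a saturated cyclohexyl group would address. As far as these compounds go, it also remains open how an ethyl group, a longer butyl chain or an amine would fare here with the 4-(trifluoromethyl)benzyl group kept in place.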